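The source may hold more compounds than are shown below. What is called first, only, known or untested is meant among the compounds shown, and "the series" means these compounds.

Compound 2 `Fc1ccccc1-c1cn2ccnc2c(-c2ccc3ncn(C4CCCCC4)c3c2)n1` stands lowest of the two numbers in a functional assay on HT-29 cells (Homo sapiens) for inhibition, read by sulforhodamine B assay, with a stated time of 48 h, tested at 10 uM; a lower number here means less inhibition, a higher number more inhibition at the concentration tested (going by the name of the read-out): compound 2 gives 7.26%, while compound 1 `O=Cc1ccc(-c2cn3ccnc3c(-c3ccc4ncn(C5CCCCC5)c4c3)n2)cc1` gives 17.5%. Among the measured compounds shown here, the one measured step, a number 10.2 percentage points lower from compound 1 to compound 2 (beyond the scatter), also exchanges the group on the shared core and so bears on the change now in view. Compound 3 `FC(F)(F)c1cccc(-c2cn3ccnc3c(-c3ccc4ncn(C5CCCCC5)c4c3)n2)c1` carries 3-(trifluoromethyl)phenyl in place of 2-fluorophenyl on an aromatic carbon. For the measured compounds named here, no measured compound carries a trifluoromethyl, so the measured step only shows that such an exchange moves the read-out modestly. The expected step is small, a number 4.7 percentage points higher from compound 2 to compound 3 (within the scatter). For compound 3 the estimate in this assay is 12%, with a range from 0% to 30%.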

Compound 3, a percentage reported as inhibition, at one concentration (the size of the read-out at that concentration, not a potency): 6.41%
Estimate against measurement, compound 3: 5.6 percentage points above, and the stated range covers the measured number.
By their numbers in this assay, from the lowest: compounds 3 and 2 (each within the scatter of the next); then compound 1.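

In this assay, 3-(trifluoromethyl)phenyl in place of 2-fluorophenyl does not separate the two groups at this position (a number 0.9 percentage points lower from compound 2 to compound 3 (within the scatter)). Replacing 4-formylphenyl with 3-(trifluoromethyl)phenyl gives a number 11.1 percentage points lower from compound 1 to compound 3 (beyond the scatter), so the difference first seen with 2-fluorophenyl recurs with a second group. On these data alone, whether this difference belongs to the formyl group or to its location on the phenyl ring stays open, as does the effect of an amine or a carboxylic acid on that ring. Nothing available here accounts for these steps.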